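The source may report more compounds than this note shows. Statements on the series, on what has been measured and on what is new or still open speak of the compounds shown alone.

Measured in an in vitro ADME assay on microsomes from liver (Rattus norvegicus) for metabolic stability, read by LC-MS, using NADPH, tested at 1 uM; on this read-out lower numbers stand for a shorter-lived compound and higher numbers for a longer-lived compound:
- compound 1 `CCN1C(=O)CN(Cc2ccc(-c3cccc(CN4CCCCC4)n3)cc2)C1=O`: 0.95 h
- compound 2 `CCN1C(=O)CN(Cc2ccc(-c3ccc(F)c(CN4CCCCC4)n3)cc2)C1=O`: 0.517 h

Compound 1 has only compound 2 to compare with, and the two sit within the scatter of each other: a 1.8-fold lower number from compound 1 to compound 2 (0.26 log units; within the scatter). Next is compound 3 `CCN1C(=O)CN(Cc2ccc(-c3cccc(CC4CCCCC4)n3)cc2)C1=O`, with cyclohexyl in place of piperidin-1-yl on a saturated chain carbon bound to an aromatic carbon. For the measured compounds named here, no measured step covers this change. The only one, a 1.8-fold lower number from compound 1 to compound 2 (0.26 log units; within the scatter), is a fluoro replacement elsewhere, so it offers weak guidance, and no shift beyond the scatter is expected. The estimated step is a 1.4-fold lower number from compound 1 to compound 3 (0.13 log units; within the scatter). For compound 3 the expected half-life is 0.7 h, with an estimated range of 0.3 h to 1.6 h.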

Compound 3, half-life: 0.117 h
For compound 3 the middle estimate is 6.0-fold (0.78 log units) above the measured one; the whole stated range lies above it.
By their numbers in this assay, from the lowest: compound 3; then compounds 2 and 1 (each within the scatter of the next).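

In this assay, the read-out responds strongly on this saturated chain carbon bound to an aromatic carbon: cyclohexyl in place of piperidin-1-yl gives an 8.1-fold lower number from compound 1 to compound 3 (0.91 log units; beyond the scatter), the only step shown that lies beyond the scatter. The change exchanges the ring nitrogen of piperidin-1-yl for carbon, so a single ring atom separates this pair. Nothing at hand bears on why the half-life differs so much.

Open, from the compounds shown here alone, is whether other amines on the same carbon, such as morpholin-4-yl or dimethylamino, stay with piperidin-1-yl or move towards cyclohexyl. Also open, going by these compounds, is how fluoro on the aromatic carbon would read with cyclohexyl in place.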